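Methyl on the ring nitrogen: projection for compound 4

The source may report more compounds than this note shows. Statements on the series, on what has been measured and on what is new or still open speak of the compounds shown alone.

Compound 1 `c1ccc2c(c1)CN[C@@H](CN(CCCN1CCNCC1)[C@H]1CCCc3cccnc31)C2` is the reference of the set. In a functional assay on CCRF-CEM cells for antagonist activity at C-X-C chemokine receptor type 4 (Homo sapiens), read by calcium flux, with stated times of 25 min and 90 s (on this read-out lower numbers stand for stronger inhibition and higher numbers for weaker inhibition), compound 1 gives 17 nM, the lowest of the three measured numbers. Compound 2 `c1cnc2c(c1)CN[C@@H](CN(CCCN1CCNCC1)[C@H]1CCCc3cccnc31)C2` gives 171 nM in this assay, with a 10-fold higher number from compound 1 to compound 2 (1.00 log units; beyond the scatter). Compound 3 `c1cnc(CN(CCCN2CCNCC2)[C@H]2CCCc3cccnc32)nc1` gives 4320 nM in this assay, with a 250-fold higher number from compound 1 to compound 3 (2.41 log units; beyond the scatter); between the two weaker compounds the step is a 25-fold higher number from compound 2 to compound 3 (1.40 log units; beyond the scatter). All three measured steps alter the group on the saturated chain carbon bound to the amine nitrogen and leave the piperazine untouched.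

Compound 4 `CN1CCN(CCCN(C[C@H]2Cc3ccccc3CN2)[C@H]2CCCc3cccnc32)CC1` differs from compound 1 in another place: methyl in place of hydrogen on an amine nitrogen in a ring, piperazin-1-yl becoming 4-methylpiperazin-1-yl. For the measured compounds named here, no measured pair changes anything on the piperazine, so none of the steps bears directly on this change; the steps to compound 2 and compound 3 only show that replacing the 1,2,3,4-tetrahydroisoquinolin-3-yl group is where large losses arise, and compound 4 keeps that group exactly as in compound 1. With no evidence pointing either way, the expected step of a 1.5-fold higher number from compound 1 to compound 4 (0.17 log units; within the scatter) is none beyond the scatter, with wide uncertainty. Compound 4 is therefore estimated at 25 nM in this assay, with a range of 7 nM to 90 nM.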

Compound 4, half-maximal inhibitory concentration: 125 nM
Compound 4: the middle estimate sits 5.0-fold (0.70 log units) below what was measured; measured number outside the range, above it.
By their numbers in this assay, from the lowest: compound 1; then compounds 4 and 2 (each within the scatter of the next); then compound 3.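

In this assay, methyl in place of hydrogen on the amine nitrogen in the piperazine ring gives a 7.4-fold higher number from compound 1 to compound 4 (0.87 log units; beyond the scatter), the first step shown that lies away from the group on the saturated chain carbon. The 1,2,3,4-tetrahydroisoquinolin-3-yl group stays as in compound 1 and the entering group is only methyl, so within this series a change beyond the scatter is not confined to that group: the piperazin-1-yl end also responds, even to this single carbon. The compounds shown offer no measurement that accounts for this step.

Still open, from the compounds shown here alone, is whether this ring nitrogen responds to size in a graded way, for which ethyl, isopropyl or acetyl in place of methyl would be the informative groups, and whether the nitrogen itself is needed, which morpholin-4-yl or piperidin-1-yl in place of piperazin-1-yl would address. Also open, going by these compounds, is whether 4-methylpiperazin-1-yl brings a similar step when combined with the groups carried by compound 2 and compound 3, or whether the two changes do not add up.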